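This account rests on a few compounds, and the source may have more. Where it says the series, first, only, none or still open, it means among the compounds named here.

Measured so far in an assay on HEK293 cells for positive allosteric modulation of metabotropic glutamate receptor 3 (Rattus norvegicus), read by thallium flux, with a stated time of 2.5 min; on this read-out higher numbers stand for larger maximal responses and lower numbers for smaller maximal responses:
compound 1 `Cc1c(OCCCCOc2ccc(C(=O)O)cc2)ccc(C(=O)CC2CCCC2)c1O`: 26.7%
compound 2 `Cc1c(OCCCCOc2ccccc2C(=O)O)ccc(C(=O)CC2CCCC2)c1O`: 32.9%
compound 3 `Cc1c(OCCCCOCOc2ccc(C(=O)O)cc2)ccc(C(=O)CC2CCCC2)c1O`: 46.9%

Compound 3 stands highest of the three in this assay; the nearest is compound 2, with a number 14 percentage points higher from compound 2 to compound 3 (beyond the scatter), and the furthest is compound 1, with a number 20.2 percentage points higher from compound 1 to compound 3 (beyond the scatter). Compound 2 against compound 1 shows a number 6.2 percentage points higher from compound 1 to compound 2 (within the scatter), so the two carboxyphenyl isomers sit together within the scatter.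

Compound 4 `Cc1cc(OCCCCOc2ccc(C(=O)CC3CCCC3)c(O)c2C)ccc1C(=O)O` is to be measured in this assay. Relative to compound 3 the change is 4-carboxy-3-methylphenyl in place of (4-carboxyphenoxy)methyl on an oxygen on a saturated carbon. The step that bears on it most directly is a number 20.2 percentage points higher from compound 1 to compound 3 (beyond the scatter): compound 1 carries 4-carboxyphenyl on the same oxygen, and compound 4 differs from compound 1 only by the added methyl of 4-carboxy-3-methylphenyl. Reversing that step, the expectation for compound 4 is a modest fall beyond the scatter, a number 16.9 percentage points lower from compound 3 to compound 4 (beyond the scatter). Among the compounds with values here, no measured pair shows what the added methyl contributes, so the range is kept wide. Compound 4 is therefore estimated at 30%, within 20% to 42%.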

Compound 4, largest response reached (reported as percent of maximum), in percent of the reference or control that the assay uses: 23.7%
Compound 4: the middle estimate sits 6.3 percentage points above what was measured; low and high end bracket the measured number.
By their numbers in this assay, from the lowest: compounds 4, 1 and 2 (each within the scatter of the next); then compound 3.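

In this assay, the added methyl on an aromatic carbon gives a number 3 percentage points lower from compound 1 to compound 4 (within the scatter), and 4-carboxy-3-methylphenyl against 2-carboxyphenyl gives a number 9.2 percentage points lower from compound 2 to compound 4 (within the scatter), so neither change separates these groups on the oxygen on a saturated carbon. The (4-carboxyphenoxy)methyl group of compound 3 therefore remains the only one here that stands apart, with a number 23.2 percentage points lower from compound 3 to compound 4 (beyond the scatter) on replacing it with 4-carboxy-3-methylphenyl. No measurement on hand gives a reason for this difference.

The compounds shown leave open whether the higher response of compound 3 belongs to the extra oxygen of its group or to the greater length, which a plain longer chain would separate. They also leave open how a tetrazole in place of the carboxylic acid, or a chlorine in place of the added methyl, would read.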